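Swapping phenyl for methoxy on a non-cytotoxic series

The source may report more compounds than this note shows. Statements on the series, on what has been measured and on what is new or still open speak of the compounds shown alone.

compound 1 `O=C(/C=C/c1ccc2c(c1)B(O)OC2)c1ccc(C(F)(F)F)cc1`: > 10 ug/mL
compound 2 `O=C(/C=C/c1ccc2c(c1)B(O)OC2)c1ccc(F)cc1`: > 10 ug/mL
compound 3 `O=C(/C=C/c1ccc2c(c1)B(O)OC2)c1ccc(-c2ccccc2)cc1`: > 10 ug/mL

In an ADME assay on L929 cells (Mus musculus) for cytotoxicity, read by resazurin assay, with a stated time of 72 h (a higher number here means a weaker inhibitor, a lower number a stronger inhibitor), compound 3 gives > 10 ug/mL, which is a limit and not a number. It stands with its two companions, and the series as a whole sits at the limit of > 10 ug/mL in this assay, at which 3 of the 3 values shown sit.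

The next compound, compound 4 `COc1ccc(C(=O)/C=C/c2ccc3c(c2)B(O)OC3)cc1`, keeps the shared core and the rest of the chain. Only the group on the outer aromatic ring changes, with methoxy in place of phenyl on an aromatic carbon, para to a large group: methoxy in place of phenyl on an aromatic carbon.

Within the data shown here, three measured steps bear on this change, all of them exchanges at the same place. They are a step that the two limits leave unreadable from compound 1 to compound 3, then a step that the two limits leave unreadable from compound 2 to compound 3, and finally a step that the two limits leave unreadable from compound 1 to compound 2. None of them gives a size, so the data offer no measured direction for such an exchange. Fluoro, trifluoromethyl and phenyl all leave the reading at the limit, and methoxy is expected to do the same in this assay, with no step beyond the scatter. The step expected is a step that the limit leaves unreadable from compound 3 to compound 4. Compound 4 is estimated at 12 ug/mL, with an expected range from 5 ug/mL to 30 ug/mL.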

Compound 4, half-maximal inhibitory concentration: > 10 ug/mL
Compound 4 ended at the assay's limit (the forecaster's own chance of this, stated with the estimate: 80%); the middle value lies beyond the limit too.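

In this assay compound 4 gives > 10 ug/mL, which is a limit and not a number. No new step can be read from compound 1, compound 2 or compound 3 to compound 4. The compounds shown leave open at what concentration any of them would reach half-maximal inhibition, and whether the outer group changes it, with the whole series at one reading: the limit of > 10 ug/mL in this assay, at which 4 of the 4 values shown sit.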